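The source may hold more compounds than are shown below. What is called first, only, known or untested is meant among the compounds shown, and "the series" means these compounds.

Measured in a physicochemical assay for lipophilicity, read by HPLC, at pH 7.4; a higher number here means a more lipophilic compound, a lower number a more polar compound:
- Compound 1 `COc1ccc(-c2cc(-c3ccc(S(C)(=O)=O)cc3)cnc2N)cn1`: 2.2
- Compound 2 `CS(=O)(=O)c1ccc(-c2cnc(N)c(-c3ccc(CO)nc3)c2)cc1`: 1.2
- Compound 3 `CS(=O)(=O)c1ccc(-c2cnc(N)c(-c3ccc(C(F)(F)F)c(F)c3)c2)cc1`: 3.1

Compound 2, at 1.2, has the lowest of the three numbers in this assay. Compound 1 stands nearest to it at 2.2, and compound 3 stands furthest at 3.1. Both gaps lie beyond the scatter.

The next compound is compound 4 `CS(=O)(=O)c1ccc(-c2cnc(N)c(-c3ccc(C#N)cc3)c2)cc1`, which differs from compound 2 by one change: 4-cyanophenyl in place of 6-(hydroxymethyl)pyridin-3-yl on an aromatic carbon. In words, 4-cyanophenyl stands in place of 6-(hydroxymethyl)pyridin-3-yl on an aromatic carbon.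

Within the data shown here, only one measured step touches the hydroxymethyl group. This is a number 1.00 log units lower from compound 1 to compound 2 (beyond the scatter), a modest step beyond the scatter that arises when hydroxymethyl takes the place of methoxy. Compound 4 loses that hydroxymethyl group, so the number is expected to rise by a similar modest amount. Among the measured compounds shown here, no measured step brings in the nitrile, so this reading is indirect. Compound 3 also carries a ring of carbon only at this place, and its 3.1 serves as a rough upper guide.

The expected change is a number 1.10 log units higher from compound 2 to compound 4 (beyond the scatter), which would lie beyond the scatter. For compound 4 the estimated value is 2.3, with an expected range from 1.8 to 2.8.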

Compound 4, distribution coefficient: 2.4
Compound 4: the middle estimate sits 0.10 log units below what was measured; measured number inside the range.
By their numbers in this assay, from the lowest: compound 2; then compounds 1 and 4 (each within the scatter of the next); then compound 3.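

Within this assay, at this aromatic carbon ortho to an amino group, exchanging the whole group gives a number 1.20 log units higher from compound 2 to compound 4 (beyond the scatter), a large step and larger than the modest one seen when only the hydroxymethyl and methoxy groups were exchanged. The other new comparison gives a number 0.20 log units higher from compound 1 to compound 4 (within the scatter) and so does not separate 4-cyanophenyl from 6-methoxypyridin-3-yl, showing that a ring of carbon only carrying a nitrile and a pyridine ring carrying methoxy can read alike here, while compound 2 stays apart from both. No supporting evidence bears on the reason for either result.

The compounds shown leave open how the large step divides between the change of ring and the change of substituent, which a nitrile on the pyridine ring or a hydroxymethyl on the ring of carbon only would help to separate. They also leave open how an aminomethyl group or a carboxylic acid would read in this assay when carried by the ring at this place.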